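Adding a methoxy group where three compounds already sit at a limit

The source may hold more compounds than are shown below. What is called first, only, known or untested is meant among the compounds shown, and "the series" means these compounds.

Compound 1, `Cc1nc(Nc2ccc(Cl)cc2)sc1C(=O)/C=C/c1ccccc1`, gives a limit rather than a number in a functional assay on BGC-823 cells (Homo sapiens) for cytotoxicity, read by MTT assay; a lower number here means a stronger inhibitor, a higher number a weaker inhibitor: > 25000 nM.
Compound 2, `COc1cccc(/C=C/C(=O)c2sc(Nc3ccc(Cl)cc3)nc2C)c1`, gives a limit in this assay as well: > 25000 nM.
Compound 3, `Cc1ccccc1Nc1nc(C)c(C(=O)/C=C/c2ccccc2)s1`, also gives a limit in this assay: > 25000 nM.

Three compounds share one core and differ in small ways. Compound 2 differs from compound 1 by methoxy in place of hydrogen on an aromatic carbon. The step that the two limits leave unreadable from compound 1 to compound 2 cannot be sized, since both values are limits. Compound 3 differs from compound 1 by 2-methylphenyl in place of 4-chlorophenyl on a nitrogen on an aromatic ring, and the step that the two limits leave unreadable from compound 1 to compound 3 is likewise unreadable for the same reason.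

Compound 4, `COc1cccc(/C=C/C(=O)c2sc(Nc3ccccc3C)nc2C)c1`, is not yet measured. It differs from compound 3 by methoxy in place of hydrogen on an aromatic carbon, and the place of this change is described in the same words as for the change from compound 1 to compound 2, so it is the same change made on a different partner. The one fact that stands out is the limit of > 25000 nM in this assay, at which 3 of the 3 values shown sit. Going by the values given here, because of the limit of > 25000 nM in this assay, at which 3 of the 3 values shown sit, the expected step that the limit leaves unreadable from compound 3 to compound 4 is set at about nothing, with the understanding that no step can really be read from limits alone. Compound 4 is therefore expected to come out near 40000 nM, most likely as another limit of this assay, with an estimated range from 12000 nM to 150000 nM.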

Compound 4, half-maximal inhibitory concentration: > 25000 nM
Compound 4 was reported as a limit; the forecaster's own chance of this, stated with the estimate: 80%; the middle value lies beyond the limit too.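

In this assay compound 4 gives > 25000 nM, which is a limit and not a number. No size can be read for the step from compound 3 to compound 4 or for the one from compound 2 to compound 4, because every compound shares the same limit: the limit of > 25000 nM in this assay, at which 4 of the 4 values shown sit.

The compounds shown leave open how strongly any of the four acts on these cells, and whether either change makes any difference.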